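A few compounds are considered here, and "the series" means these few. Any claim that something is new, unique, unknown or untested is made for them only; others in the source may bear on it.

Three measured compounds share one core and differ only in the group attached to an aromatic nitrogen of that core. Compound 1 `CCCn1c(-c2ccc(OCc3c(-c4c(Cl)cccc4Cl)noc3C(C)C)cc2)nc2ccc(C(=O)O)cc21` carries a propyl group there; in an assay on Huh-7 cells for agonist activity at Bile acid receptor (Homo sapiens), read by a luciferase reporter (on this read-out higher numbers stand for an effect only at larger amounts of compound and lower numbers for an effect already at smaller amounts), compound 1 gives 9.3 nM. Compound 2 `CCCC(CCC)n1c(-c2ccc(OCc3c(-c4c(Cl)cccc4Cl)noc3C(C)C)cc2)nc2ccc(C(=O)O)cc21` carries a 1-propylbutyl group, and compound 2 gives 1.8 nM, a step of a 5.2-fold lower number from compound 1 to compound 2 (0.71 log units; beyond the scatter). Compound 3 `CC(C)c1onc(-c2c(Cl)cccc2Cl)c1COc1ccc(-c2nc3ccc(C(=O)O)cc3n2C2CCCCCC2)cc1` carries a cycloheptyl group; compound 3 gives 14.8 nM, which is the highest of the three numbers, yet the step of a 1.6-fold higher number from compound 1 to compound 3 (0.20 log units; within the scatter) is within the scatter, while the step of an 8.2-fold higher number from compound 2 to compound 3 (0.91 log units; beyond the scatter) is not.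

Compound 4 `CC(C)c1onc(-c2c(Cl)cccc2Cl)c1COc1ccc(-c2nc3ccc(C(=O)O)cc3n2C2CCCCC2)cc1` is the next step: cyclohexyl in place of cycloheptyl on an aromatic nitrogen. Among the measured compounds shown here, no measured step removes a single carbon from a ring on this nitrogen. The closest guidance is that propyl and cycloheptyl on this position gave numbers within the scatter of one another, and that only the branched 1-propylbutyl stood apart. A shrinking of the ring by one carbon is therefore expected to move the number little, if at all: the expected step is a 1.5-fold lower number from compound 3 to compound 4 (0.17 log units; within the scatter). Compound 4 is estimated at 10 nM, within a range from 4 nM to 25 nM.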

Compound 4, half-maximal effective concentration: 4.21 nM
Compound 4: middle estimate off by 2.4-fold (0.38 log units), on the high side; the measured number falls inside the stated range.
By their numbers in this assay, from the lowest: compound 2; then compound 4; then compounds 1 and 3 (each within the scatter of the next).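

Within this assay, ring size on this aromatic nitrogen matters: going from cycloheptyl to cyclohexyl gives a 3.5-fold lower number from compound 3 to compound 4 (0.55 log units; beyond the scatter), so losing a single ring carbon produces a real change. The cyclohexyl group also separates from propyl, with a 2.2-fold lower number from compound 1 to compound 4 (0.34 log units; beyond the scatter), but does not match 1-propylbutyl, with a 2.3-fold higher number from compound 2 to compound 4 (0.37 log units; beyond the scatter); the numbers therefore do not simply follow group size, since propyl and cycloheptyl remain within the scatter of each other while cyclohexyl lies beyond the scatter from both. Nothing given here accounts for these differences.

Open, from the compounds shown here alone, is whether cyclopentyl would continue the change seen on shrinking the ring or reverse it. Also open, going by these compounds, is how a shorter branched group such as isopropyl, or a six-membered ring containing oxygen such as tetrahydropyranyl, would compare with cyclohexyl.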